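The compounds below may be only part of what the source reports. "The series", "measured", "known", "first", "only" and "open" are said of these compounds alone.

Series notes. Compound 1 `COc1ccc(C#Cc2csc(C)n2)cn1` and compound 2 `Cc1nc(C#Cc2ccc(OS(C)(=O)=O)nc2)cs1` share one core; compound 3 `COc1ncccc1C#Cc1csc(C)n1` and the not yet measured compound 4 `Cc1nc(C#Cc2cccnc2OS(C)(=O)=O)cs1` share a second one. The difference between the two cores is not broken down here. In a functional assay on CHO cells for agonist activity at metabotropic glutamate receptor 5 (Homo sapiens), read by inositol phosphate accumulation (on this read-out higher numbers stand for weaker inhibition and lower numbers for stronger inhibition), compound 1 gives 426 nM, compound 2 gives 2340 nM and compound 3 gives 228 nM. Compound 3 and compound 1 lie within the scatter of each other; compound 2 stands beyond it from both.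

On the first core the change methylsulfonyl in place of methyl on an oxygen on an aromatic ring gave a 5.5-fold higher number from compound 1 to compound 2 (0.74 log units; beyond the scatter). The same change, (methylsulfonyl in place of methyl on an oxygen on an aromatic ring), carries compound 3 to compound 4; the two place descriptions read alike, so it is the same change set on a different core. It occurs in two pairs among these compounds, with only one pair measured, so the expectation for compound 4 rests on that single step, a 5.5-fold higher number from compound 1 to compound 2 (0.74 log units; beyond the scatter), and on the single value of compound 3, 228 nM. Compound 4 is therefore expected to show a 5.5-fold higher number from compound 3 to compound 4 (0.74 log units; beyond the scatter) in this assay. Compound 4 is accordingly estimated at 1250 nM, expected to fall between 500 nM and 3500 nM.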

Compound 4, half-maximal inhibitory concentration: > 10000 nM
Compound 4 ended at the assay's limit (the forecaster's own chance of this, stated with the estimate: 3%); middle value at least 8.0-fold (0.90 log units) from the limit.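

In this assay compound 4 gives > 10000 nM as a limit of the assay and not as a number. On the second core, methylsulfonyl in place of methyl on an oxygen on an aromatic ring gives an at least 43-fold higher number from compound 3 to compound 4 (1.64 log units; beyond the scatter) and so keeps the direction seen on the first core, but the size of the step does not carry over: the same change on two cores in this assay, a 5.5-fold higher number (0.74 log units; beyond the scatter) from compound 1 to compound 2 and an at least 43-fold higher number (1.64 log units; beyond the scatter) from compound 3 to compound 4, at least 7.9-fold (0.90 log units) apart, beyond the scatter of two such steps. The step on the second core has only a lower bound, and two pairs do not show which difference between the cores goes with the larger step, so no general rule for carrying this change follows: the limit of > 10000 nM in this assay, at which 1 of the 4 values shown sits.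

The compounds shown leave open how far the number on the second core actually rises, and whether the gap between the two steps is specific to methylsulfonyl. An acetyl group on the same oxygen, or an amine in place of methoxy, set on both cores, would be needed to tell whether other groups follow the same split.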